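Swapping an Aryl Ketone for Trifluoromethyl on the Shared Core

The source may hold more compounds than are shown below. What is called first, only, known or untested is meant among the compounds shown, and "the series" means these compounds.

Compound 1: `CC1(C)C=C(n2ccccc2=O)c2cc(C(=O)c3ccccc3[N+](=O)[O-])ccc2O1`, 5.64
Compound 2: `Cc1ccccc1C(=O)c1ccc2c(c1)C(n1ccccc1=O)=CC(C)(C)O2`, 6.25

Both compounds were tested in a functional assay (trachea) with Rattus norvegicus as the target; on this read-out higher numbers stand for higher potency (the scale is a negative logarithm) and lower numbers for lower potency. Compound 2 stands highest of the two numbers measured; its nearest neighbour is compound 1, and the change was a number 0.61 log units higher from compound 1 to compound 2 (beyond the scatter), which came from a methyl in place of a nitro on an aromatic carbon.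

Compound 3 is `CC1(C)C=C(n2ccccc2=O)c2cc(C(F)(F)F)ccc2O1`. It differs from compound 2 in one place: trifluoromethyl in place of (2-methylphenyl)carbonyl on an aromatic carbon. For the measured compounds named here, no measured step bears directly on this change. Going by the values given here, the only step seen, a number 0.61 log units higher from compound 1 to compound 2 (beyond the scatter), altered a substituent on the ring that now leaves entirely, so it gives little guidance on direction. Among the compounds with values here, with no comparable precedent, the expected step of a number 0.25 log units lower from compound 2 to compound 3 (within the scatter) is modest and uncertain in sign. Compound 3 is therefore estimated at 6, in the range 5.2 to 6.8.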

Compound 3, logarithm of the reciprocal of the active concentration, log(1/C): 7.37
For compound 3 the middle estimate is 1.37 log units below the measured one; measured number outside the range, above it.
By their numbers in this assay, from the lowest: compound 1; then compound 2; then compound 3.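

In this assay, the step of a number 1.12 log units higher from compound 2 to compound 3 (beyond the scatter) shows that the whole (2-methylphenyl)carbonyl group can leave this aromatic carbon with a large gain rather than a loss. The earlier step of a number 0.61 log units higher from compound 1 to compound 2 (beyond the scatter) changed only a substituent on the aromatic ring of that group, whereas this result shows that neither that ring nor its carbonyl is required for potency on the shared core. Nothing measured here gives a reason for this rise.

Still open, as far as these compounds go, is whether trifluoromethyl itself matters, or whether a nitrile, a chlorine atom or a plain methyl on this aromatic carbon would serve as well. Also open, from the compounds shown here alone, is whether an acetyl group, which keeps the carbonyl but has no aromatic ring, would land nearer compound 2 or compound 3.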